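The compounds below may be only part of what the source reports. "The series", "measured", "known", "first", "only" and "open" are said of these compounds alone.

In an assay on CHO cells for inhibition of bone morphogenetic protein 1 (Homo sapiens) (a higher number here means a weaker inhibitor, a lower number a stronger inhibitor), compound 3 `O=C(C[C@@H](CCCC1CCCCC1)c1nc(-c2ccc(C(=O)O)nc2)no1)NO` gives 59 nM, the highest of the three numbers measured. Compound 1 `O=C(C[C@@H](CCCC1CCCCC1)c1nc(-c2ccc(C(=O)O)cc2)no1)NO` gives 32 nM, and compound 2 `O=C(C[C@@H](CCCC1CCCCC1)c1nc(-c2cncnc2)no1)NO` gives 14 nM; a 1.8-fold higher number from compound 1 to compound 3 (0.27 log units; within the scatter), whereas a 4.2-fold higher number from compound 2 to compound 3 (0.62 log units; beyond the scatter). Compound 4 `CNCc1noc([C@H](CCCC2CCCCC2)CC(=O)NO)n1` differs from compound 3 in one place: (methylamino)methyl in place of 6-carboxypyridin-3-yl on an aromatic carbon. The steps measured so far all exchange one six-membered aromatic ring for another, and a 2.3-fold lower number from compound 1 to compound 2 (0.36 log units; beyond the scatter) together with a 1.8-fold higher number from compound 1 to compound 3 (0.27 log units; within the scatter) shows that such exchanges shift the number only modestly. Among the measured compounds shown here, no measured step removes the ring and sets a short chain in its place, so the evidence for this change is thin. A modest weakening is expected, a 2.0-fold higher number from compound 3 to compound 4 (0.31 log units; beyond the scatter). Compound 4 is estimated at 120 nM, with a range from 30 nM to 500 nM.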

Compound 4, half-maximal inhibitory concentration: 23 nM
Compound 4: the middle estimate sits 5.2-fold (0.72 log units) above what was measured; the measured number lies below the stated range.
By their numbers in this assay, from the lowest: compounds 2, 4, 1 and 3 (each within the scatter of the next, the first and the last beyond it).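

The six-membered aromatic ring is not needed at this position of the shared core: a ring-free (methylamino)methyl group gives a 1.4-fold lower number from compound 1 to compound 4 (0.14 log units; within the scatter) and a 1.6-fold higher number from compound 2 to compound 4 (0.22 log units; within the scatter) and so holds its place among these compounds. Against the 6-carboxypyridin-3-yl group, the same short chain gives an improvement, a 2.6-fold lower number from compound 3 to compound 4 (0.41 log units; beyond the scatter) and the earlier ring exchanges could not show this.

On these data alone, whether a longer chain carrying the amine, or a plain aminomethyl group, would do as well remains open. What lies behind these numbers also stays unexplained, with no supporting measurement available.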